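The compounds below may be only part of what the source reports. "The series", "measured", "known", "first", "only" and "open" are said of these compounds alone.

In a functional assay on MV4-11 cells (Homo sapiens) for inhibition, read by resazurin assay, with a stated time of 72 h (on this read-out lower numbers stand for stronger inhibition of growth and higher numbers for weaker inhibition of growth), compound 1 `Cc1ccc(-c2cncc(Cl)c2N2CCC3(CCNC3=O)CC2)o1` gives 4950 nM and compound 2 `Cc1csc(-c2cncc(Cl)c2N2CCC3(CCNC3=O)CC2)c1` gives 650 nM, so compound 2 holds the lower of the two numbers. Compound 3 `CC(=O)c1ccc(-c2cncc(Cl)c2N2CCC3(CCNC3=O)CC2)s1` carries 5-acetylthiophen-2-yl in place of 4-methylthiophen-2-yl on an aromatic carbon, (5-acetylthiophen-2-yl in place of 4-methylthiophen-2-yl on an aromatic carbon). Within the data shown here, only one measured step bears on this: a 7.6-fold lower number from compound 1 to compound 2 (0.88 log units; beyond the scatter), a modest change at the same place, beyond the scatter. Among the measured compounds shown here, it gives no direction for the acetyl group, so a modest move towards a higher number in this assay is expected, no larger than that step. The expected step is a 1.5-fold higher number from compound 2 to compound 3 (0.19 log units; within the scatter). For compound 3 the estimated value is 1000 nM, within a range of 300 nM to 3300 nM.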

Compound 3, concentration for 50% growth inhibition: 1440 nM
Beside the measured number, compound 3's estimate is 1.4-fold (0.16 log units) below it; measured number inside the range.
By their numbers in this assay, from the lowest: compound 2; then compound 3; then compound 1.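

In this assay, the acetyl-bearing thiophene gives up some of the level reached with the methyl-bearing one (a 2.2-fold higher number from compound 2 to compound 3 (0.35 log units; beyond the scatter)), yet it keeps an advantage over the furan (a 3.4-fold lower number from compound 1 to compound 3 (0.54 log units; beyond the scatter)). Both thiophenes thus have lower numbers than the furan, with the substituent on the thiophene still shifting the result. No measurement here accounts for these differences. The compounds shown leave open whether the acetyl group itself or its ring location drives the rise, since both differ between compound 2 and compound 3. They also leave open how a 5-methylthiophen-2-yl group, an amine or a carboxylic acid on the thiophene would behave.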